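Benzoate in Place of Acetate on a Lactone Core

The compounds below may be only part of what the source reports. "The series", "measured", "known", "first", "only" and "open" are said of these compounds alone.

Compound 2 `CC(=O)O[C@@H]1OC(=O)[C@](OC(C)=O)(C(C)=O)[C@@H]1C` carries an acetate on a ring carbon of its lactone core. In a functional assay on B16 cells (Mus musculus) for cytotoxicity, read by MTT assay (a lower number here means a stronger inhibitor, a higher number a weaker inhibitor), compound 2 gives > 50000 nM, which is a limit of the assay rather than a number. Compound 1 `CC(=O)O[C@@H]1OC(=O)[C@@](C(C)=O)(C2SCCCS2)[C@@H]1C` differs from compound 2 in one place, and in this assay compound 1 gives > 50000 nM, again a limit. The step that the two limits leave unreadable from compound 1 to compound 2 cannot be read in size because of the limit of > 50000 nM in this assay, at which 2 of the 2 values shown sit. Compound 3 `CC(=O)O[C@@H]1OC(=O)[C@](OC(=O)c2ccccc2)(C(C)=O)[C@@H]1C` has not yet been measured; it differs from compound 2 by phenyl in place of methyl on a carbonyl carbon. Among the compounds with values here, no measured step exchanges a phenyl for a methyl here, so the two values seen offer only a floor and no sense of how large such a change might be in this assay. Compound 3 is therefore expected to stay near or beyond that limit, a step that the limit leaves unreadable from compound 2 to compound 3. The estimate for compound 3 is 60000 nM, with a range from 15000 nM to 250000 nM.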

Compound 3, half-maximal inhibitory concentration: 6000 nM
The estimate for compound 3 lay 10-fold (1.00 log units) above the measured number; the measured number lies below the stated range.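

In this assay, phenyl in place of methyl on a carbonyl carbon gives an at least 8.3-fold lower number from compound 2 to compound 3 (0.92 log units; beyond the scatter). Within the data shown here, compound 3, at 6000 nM, is the only one of the three compounds with a measured number rather than a limit of the assay, so a change at this one place is enough to bring the series into the range where the assay can give a number. The full size of the new step remains unknown, and the step between compound 1 and compound 2 cannot be read at all: the limit of > 50000 nM in this assay, at which 2 of the 3 values shown sit.

Going by these compounds, it remains open whether the aromatic ring itself matters or whether a longer chain, such as butyl, would lower the number as well. Also open, on these data alone, is how a pyridine ring in place of the phenyl, or a methoxy group added to it, would change the number.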